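The compounds below may be only part of what the source reports. "The series", "measured", "known", "first", "only" and "open" are said of these compounds alone.

Compound 1 `COc1ccc(/C=C/C(=O)O)c(OC(=O)c2nc(C)c(C)nc2C)c1` and compound 2 `COc1ccc(OC(=O)c2nc(C)c(C)nc2C)c(/C=C/C(=O)O)c1` are built from the same atoms joined differently; the difference between the two cores is not broken down here. In a functional assay on EA.hy 926 cells (Homo sapiens) for cytotoxicity, read by MTT assay, with stated times of 24 h and 12 h, tested at 100 uM (a higher number here means a stronger effect of the compound at the concentration tested, a lower number a weaker effect), compound 1 gives 18%, while compound 2 gives 79.2%, the highest of the three measured numbers. Compound 3 `CCOC(=O)/C=C/c1ccc(OC)cc1OC(=O)c1nc(C)c(C)nc1C` differs from compound 1 by ethyl in place of hydrogen on an oxygen next to a carbonyl group, and in this assay compound 3 gives 39.9%; the step of a number 21.9 percentage points higher from compound 1 to compound 3 (beyond the scatter) is modest but beyond the scatter. Compound 4 `CCOC(=O)/C=C/c1cc(OC)ccc1OC(=O)c1nc(C)c(C)nc1C` is not yet measured. It arises from compound 2 by ethyl in place of hydrogen on an oxygen next to a carbonyl group, the same change at the same place that turned compound 1 into compound 3. On the strength of that step an increase is expected for compound 4, a number 8.8 percentage points higher from compound 2 to compound 4 (within the scatter). The high value of compound 2 in this assay, 79.2%, leaves less room upward than compound 1 had. Compound 4 is therefore estimated at 88%, between 70% and 100%.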

Compound 4, a percentage reported as activity, at one concentration (the size of the read-out at that concentration, not a potency): 46.2%
The estimate for compound 4 lay 41.8 percentage points above the measured number; measured number outside the range, below it.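

In this assay, placing ethyl in place of hydrogen on an oxygen next to a carbonyl group gives a number 33 percentage points lower from compound 2 to compound 4 (beyond the scatter), the opposite direction to the earlier step on the other core: the same change on two cores in this assay, a number 21.9 percentage points higher (beyond the scatter) from compound 1 to compound 3 and a number 33 percentage points lower (beyond the scatter) from compound 2 to compound 4, 54.9 percentage points apart, beyond the scatter of two such steps

Within these two pairs, then, the change from carboxy to ethoxycarbonyl does not carry over from one core to the other, and its effect cannot be read from one core alone. The two pairs do not show why the cores differ, or whether the reversal would hold for any other change at this place.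

The compounds shown leave open how a methyl ester, a longer chain on that oxygen or an amide in place of the ester would behave on either core. They also leave open whether the two cores would compare in the same way at other concentrations.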